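The source may hold more compounds than are shown below. What is called first, only, known or untested is meant among the compounds shown, and "the series" means these compounds.

Compounds measured in a functional assay on HOS-TE85 cells (Homo sapiens) for inhibition, read by CCK-8 assay, with a stated time of 72 h; on this read-out higher numbers stand for weaker inhibition and lower numbers for stronger inhibition:
compound 1 `COc1ccc(OC)c(N2C(=O)CSC2c2cccc(C(=O)NCCCCc3ccccc3)c2)c1` gives > 1000 nM in this assay, a limit of the assay and not a number.
compound 2 `C#Cc1cccc(N2C(=O)CSC2c2cccc(C(=O)NCCCCc3ccccc3)c2)c1` gives 149 nM in this assay.
compound 3 `O=C(NCCCCn1cccn1)c1cccc(C2SCC(=O)N2c2ccncc2)c1` gives > 1000 nM in this assay, again a limit and not a number.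

Among the measured compounds shown here, compound 2 is therefore the only compound with a numerical value; the other two sit at the limit described in the limit of > 1000 nM in this assay, at which 2 of the 3 values shown sit. For the measured compounds named here, the one measured step, an at least 6.7-fold lower number from compound 1 to compound 2 (0.82 log units; beyond the scatter), shows that the 3-ethynylphenyl group gives a markedly lower number than 2,5-dimethoxyphenyl on the amide-type nitrogen in the ring.

Compound 4 `COc1ccc(F)cc1N1C(=O)CSC1c1cccc(C(=O)NCCCCc2ccccc2)c1` has not yet been measured. It differs from compound 2 in one place: 5-fluoro-2-methoxyphenyl in place of 3-ethynylphenyl on an amide-type nitrogen in a ring. The group that enters, 5-fluoro-2-methoxyphenyl, keeps a methoxy on the phenyl as in compound 1, while the 3-ethynylphenyl of compound 2 is lost. Since the step of an at least 6.7-fold lower number from compound 1 to compound 2 (0.82 log units; beyond the scatter) ran toward lower numbers, and the change here removes the 3-ethynylphenyl that carried it, compound 4 is expected to show a 4.0-fold higher number from compound 2 to compound 4 (0.60 log units; beyond the scatter) in this assay, a move toward weaker inhibition, with a fair chance that only the limit is reported. Compound 4 is thus estimated at 600 nM, within the range 200 nM to 1800 nM.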

Compound 4, half-maximal inhibitory concentration in the HOS-TE85 assay: 8.8 nM
Beside the measured number, compound 4's estimate is 68-fold (1.83 log units) above it; the whole stated range lies above it.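

In the HOS-TE85 assay, the step of a 17-fold lower number from compound 2 to compound 4 (1.23 log units; beyond the scatter) shows that the 3-ethynylphenyl is not needed for a low number on the amide-type nitrogen in a ring, and that a phenyl carrying a methoxy can serve there with 5-fluoro-2-methoxyphenyl in place. The step of an at least 110-fold lower number from compound 1 to compound 4 (2.05 log units; beyond the scatter) shows that fluoro in place of methoxy on a single aromatic carbon is enough to separate two otherwise identical compounds by a large margin. In a physicochemical assay for solubility, read by turbidimetry, measured as kinetic solubility, at pH 6.8 (a higher number here means a more soluble compound, a lower number a less soluble compound), compound 2 gives 10000 nM and compound 4 gives 10000 nM, and the step of no change at the digits printed from compound 2 to compound 4 (within the scatter) leaves this read-out without a difference.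

Going by these compounds, how far compound 1 truly lies stays open, since its value is a limit of the assay and not a number: the limit of > 1000 nM in the HOS-TE85 assay, at which 2 of the 4 values shown sit. On these data alone, whether chloro or hydroxyl in place of the fluoro, or 5-fluoro-2-methoxyphenyl on the core of compound 3, would keep the number this low also remains open.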